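Swapping a chlorine for a methyl on the benzyl ring

A few compounds are considered here, and "the series" means these few. Any claim that something is new, unique, unknown or untested is made for them only; others in the source may bear on it.

In an assay on isolated protein for displacement of a labelled ligand from D(4) dopamine receptor (Homo sapiens) (a higher number here means a weaker inhibitor, a lower number a stronger inhibitor), compound 3 `O=C(NC1CCN(Cc2ccc(Cl)cc2)CC1)c1ccc2ccccc2c1` gives 37 nM, the low end of the three measured numbers. Compound 2 `Cc1ccc(CN2CCC(NC(=O)c3cccc4ccccc34)CC2)cc1` gives 69 nM in this assay, within the scatter of compound 3, while compound 1 `Cc1cccc(CN2CCC(NC(=O)c3cccc4ccccc34)CC2)c1` gives 77 nM, a gap just beyond the scatter. Compound 4 `Cc1ccccc1CN1CCC(NC(=O)c2ccc3ccccc3c2)CC1` differs from compound 3 by 2-methylphenyl in place of 4-chlorophenyl on a saturated chain carbon bound to an amine nitrogen in a ring. Among the measured compounds shown here, the one measured step of a related kind exchanges one methylphenyl for another: a 1.1-fold lower number from compound 1 to compound 2 (0.05 log units; within the scatter). That step is small, and the difference between compounds 2 and 3 also lies within the scatter, so only a small step, if any, is expected here. The expected step is a 1.6-fold higher number from compound 3 to compound 4 (0.21 log units; within the scatter). Compound 4 is estimated at 60 nM, with a range from 25 nM to 150 nM.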

Compound 4, inhibition constant: 26 nM
Beside the measured number, compound 4's estimate is 2.3-fold (0.36 log units) above it; the range from low to high includes it.
By their numbers in this assay, from the lowest: compounds 4, 3, 2 and 1 (each within the scatter of the next, the first and the last beyond it).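

In this assay, the exchange of 4-chlorophenyl for 2-methylphenyl gives a 1.4-fold lower number from compound 3 to compound 4 (0.15 log units; within the scatter). The earlier step moved only a methyl around the ring, a 1.1-fold lower number from compound 1 to compound 2 (0.05 log units; within the scatter), whereas this one changes both the group on the ring and where it sits. Even so, the two compounds cannot be told apart, so this place accepts either ring, and no measurement offered here explains that. Still open, as far as these compounds go, is whether the same holds for a ring carrying an amine or a carboxylic acid. From the compounds shown here alone, the effect of a longer chain between that ring and the ring nitrogen is also open.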